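A few compounds are considered here, and "the series" means these few. Any claim that something is new, unique, unknown or untested is made for them only; others in the source may bear on it.

In a functional assay on the whole organism for positive allosteric modulation, with Mus musculus as the target (a lower number here means that less compound is needed, a higher number that more compound is needed for the effect), compound 3 `CCCN(CCC)C1CCCC1N(C(=O)CC)c1ccc(Cl)c(Cl)c1` gives 2 mg/kg, the highest number of the three measured, against compound 1 `CCC(=O)N(c1ccc(Cl)c(Cl)c1)C1CCCC1O` at 0.4 mg/kg and compound 2 `CCC(=O)N(c1ccc(Cl)c(Cl)c1)C1CCCC1N` at 0.02 mg/kg. Compound 4 `C=CCN(C)C1CCCC1N(C(=O)CC)c1ccc(Cl)c(Cl)c1` is still unmeasured. It carries allyl(methyl)amino in place of dipropylamino on a saturated ring carbon. Among the measured compounds shown here, two measured steps bear on this change, both beyond the scatter: the large 100-fold higher number from compound 2 to compound 3 (2.00 log units; beyond the scatter) and the modest 5.0-fold higher number from compound 1 to compound 3 (0.70 log units; beyond the scatter). Neither isolates the new group, but allyl(methyl)amino remains a substituted amino group like that of compound 3, so only part of the large step is expected to be recovered. A modest move to a lower number is expected, a 2.9-fold lower number from compound 3 to compound 4 (0.46 log units; beyond the scatter). For compound 4 the estimate is 0.7 mg/kg, with an expected range of 0.15 mg/kg to 3 mg/kg.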

Compound 4, dose for half-maximal effect: 0.2 mg/kg
For compound 4 the middle estimate is 3.5-fold (0.54 log units) above the measured one; the measured number falls inside the stated range.
By their numbers in this assay, from the lowest: compound 2; then compounds 4 and 1 (each within the scatter of the next); then compound 3.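

At this position on the saturated ring carbon, a substituted amino group does not have to give a number as high as that of compound 3: allyl(methyl)amino in place of dipropylamino gives a 10-fold lower number from compound 3 to compound 4 (1.00 log units; beyond the scatter). Substitution still separates it from the free amino group, with a 10-fold higher number from compound 2 to compound 4 (1.00 log units; beyond the scatter), while against hydroxy the change gives a 2.0-fold lower number from compound 1 to compound 4 (0.30 log units; within the scatter), so the two groups are not told apart here. No evidence is available on what underlies these steps.

Going by these compounds, it remains open whether the double bond or the smaller group accounts for the step. Methyl(propyl)amino and dimethylamino at this position would separate the two.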